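A methyl moved, then exchanged for chlorine

The source may report more compounds than this note shows. Statements on the series, on what has been measured and on what is new or still open speak of the compounds shown alone.

Measured so far in a functional assay on K562 cells (Homo sapiens) for cytotoxicity, read by MTT assay, with a stated time of 48 h; a higher number here means a weaker inhibitor, a lower number a stronger inhibitor:
compound 1 `Cc1ccccc1CN1CCN(C(=O)CN[C@H]2CCN(S(=O)(=O)Cc3ccccc3)C2)CC1` gives 10200 nM
compound 2 `Cc1cccc(CN2CCN(C(=O)CN[C@H]3CCN(S(=O)(=O)Cc4ccccc4)C3)CC2)c1` gives 11300 nM
compound 3 `Cc1ccc(CN2CCN(C(=O)CN[C@H]3CCN(S(=O)(=O)Cc4ccccc4)C3)CC2)cc1` gives 8200 nM

All three share the same core and differ only in where a methyl sits on a phenyl ring attached to a saturated chain carbon bound to an amine nitrogen in a ring. Compound 3 has the lowest number of the three, but none of the steps separating it from the others is beyond the scatter: a 1.2-fold lower number from compound 1 to compound 3 (0.09 log units; within the scatter), a 1.4-fold lower number from compound 2 to compound 3 (0.14 log units; within the scatter), and between the other two a 1.1-fold higher number from compound 1 to compound 2 (0.04 log units; within the scatter). Shifting the methyl around the ring therefore made no difference that can be trusted.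

Compound 4 `O=C(CN[C@H]1CCN(S(=O)(=O)Cc2ccccc2)C1)N1CCN(Cc2cccc(Cl)c2)CC1` is not yet measured. Its change from compound 3 is 3-chlorophenyl in place of 4-methylphenyl on a saturated chain carbon bound to an amine nitrogen in a ring. The measured steps speak only to the position of a substituent on this ring, and all were within the scatter; the exchange of methyl for chlorine has no precedent among these compounds. In this assay compound 4 is expected to give about 8500 nM, within 4000 nM to 18000 nM. The expected step is a 1.0-fold higher number from compound 3 to compound 4 (0.02 log units; within the scatter), not beyond the scatter.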

Compound 4, half-maximal inhibitory concentration: 8600 nM
Compound 4: middle estimate off by 1.0-fold (0.01 log units), on the low side; the measured number falls inside the stated range.
By their numbers in this assay, from the lowest: compounds 3, 4, 1 and 2 (each within the scatter of the next).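

Exchanging the 4-methylphenyl for a 3-chlorophenyl changes both the substituent and its place on the ring, yet in this assay the step stays within the scatter (a 1.0-fold higher number from compound 3 to compound 4 (0.02 log units; within the scatter)). Chloro in place of methyl on an aromatic carbon, with the place on the ring kept, also stays within it (a 1.3-fold lower number from compound 2 to compound 4 (0.12 log units; within the scatter)), as does the step from the 2-methylphenyl (a 1.2-fold lower number from compound 1 to compound 4 (0.07 log units; within the scatter)). So at this position on a saturated chain carbon bound to an amine nitrogen in a ring, chlorine can stand in for methyl with no difference that can be trusted, and no measurement at hand offers an explanation.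

From the compounds shown here alone, it remains open whether an amine or a carboxylic acid on this phenyl ring would shift the number beyond the scatter. The same question stands for a longer chain in place of the benzyl group.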